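Acetyl in Place of Trifluoromethoxy: The Next Step

The source may hold more compounds than are shown below. What is called first, only, known or untested is meant among the compounds shown, and "the series" means these compounds.

Measured so far:
compound 1 `COc1ccc(-c2ccc(OCc3cc(C(=O)O)oc3C)cc2)nc1` gives 1300 nM
compound 2 `Cc1oc(C(=O)O)cc1COc1ccc(-c2ccc(OC(F)(F)F)cc2)cc1` gives 2400 nM

Both numbers come from an assay on cells for displacement of a labelled ligand from prostaglandin E2 receptor EP4 subtype (Homo sapiens), read by scintillation counting; on this read-out lower numbers stand for stronger inhibition and higher numbers for weaker inhibition. Compound 2 shows the higher of the two, yet its gap to compound 1 lies within the scatter, so neither can be placed ahead of the other. Compound 3 `CC(=O)c1ccc(-c2ccc(OCc3cc(C(=O)O)oc3C)cc2)cc1` has not been measured. It differs from compound 2 in one place: acetyl in place of trifluoromethoxy on an aromatic carbon. For the measured compounds named here, no measured pair shows what this exchange does, so the expectation rests on compound 2 alone. A step of a 1.3-fold lower number from compound 2 to compound 3 (0.12 log units; within the scatter) is expected, which is no change beyond the scatter. The estimate for compound 3 is therefore 1800 nM, ranging from 500 nM to 6000 nM.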

Compound 3, inhibition constant: 150 nM
Compound 3: middle estimate off by 12-fold (1.08 log units), on the high side; the measured number lies below the stated range.
By their numbers in this assay, from the lowest: compound 3; then compounds 1 and 2 (each within the scatter of the next).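

The group on this aromatic carbon, para to a large group, can matter a great deal: acetyl in place of trifluoromethoxy gives a 16-fold lower number from compound 2 to compound 3 (1.20 log units; beyond the scatter), a large step beyond the scatter. The two groups have the same counts of hydrogen-bond donors and acceptors, so those counts do not separate them. No measurement at hand explains the step.

Still open, going by these compounds, is whether an amide, a nitrile or a longer ketone chain here would match acetyl. Also open, on these data alone, is whether acetyl would give a similar step in other cores.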